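Anilino for hydroxy on the double-bonded nitrogen

The compounds below may be only part of what the source reports. "The series", "measured", "known", "first", "only" and "open" are said of these compounds alone.

Working notes on the series. Activity is followed in a functional assay, read by spectrophotometry, with a stated time of 5 min; a lower number here means a stronger inhibitor, a higher number a weaker inhibitor. Compound 1 `O=c1cc(/C=N\O)c2c(OCc3ccccc3)cc(OCc3ccccc3)cc2o1` gives in this assay > 2000000 nM, which is a limit of the assay and not a number, and it sits at the threshold described under (the limit of > 2000000 nM in this assay, at which 1 of the 3 values shown sits). Two hydrazone-type neighbours give numbers: compound 2 `N/N=C\c1cc(=O)oc2cc(OCc3ccccc3)ccc12`, on a related core, gives in this assay 131000 nM, and, on the core shared with compound 1, compound 3 `O=c1cc(/C=N\Nc2ccc([N+](=O)[O-])cc2[N+](=O)[O-])c2c(OCc3ccccc3)cc(OCc3ccccc3)cc2o1` gives in this assay 292000 nM. Going by the values given here, no single-point step between measured compounds exists in the set, so the size of any step is an expectation only.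

The unmeasured compound 4 `O=c1cc(/C=N\Nc2ccccc2)c2c(OCc3ccccc3)cc(OCc3ccccc3)cc2o1` differs from compound 1 by anilino in place of hydroxy on a double-bonded nitrogen. Since compound 3 carries a substituted anilino on the same nitrogen and gives 292000 nM, compound 4 is expected to give a measurable number, the expected step from compound 1 to compound 4 being an at least 6.6-fold lower number from compound 1 to compound 4 (0.82 log units; beyond the scatter), clearly beyond the scatter. Compound 4 is therefore estimated at 300000 nM, within 100000 nM to 1500000 nM, in this assay.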

Compound 4, half-maximal inhibitory concentration: 303000 nM
Beside the measured number, compound 4's estimate is 1.0-fold (0.00 log units) below it; the measured number falls inside the stated range.
By their numbers in this assay, from the lowest: compound 2; then compounds 3 and 4 (each within the scatter of the next). At a limit, above all of these: compound 1.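

Anilino in place of hydroxy on a double-bonded nitrogen gives an at least 6.6-fold lower number from compound 1 to compound 4 (0.81 log units; beyond the scatter) in this assay and so brings the shared core to a measurable number. Compound 1 stands at a limit of the assay and not at a number: the limit of > 2000000 nM in this assay, at which 1 of the 4 values shown sits.

Phenyl in place of 2,4-dinitrophenyl on an amine nitrogen gives a 1.0-fold higher number from compound 3 to compound 4 (0.02 log units; within the scatter) in this assay and so, on this core, the two nitro groups make no difference that can be read beyond the scatter.

As far as these compounds go, it stays open whether the step from hydroxy needs the phenyl ring at all, since a plain amino group on the double-bonded nitrogen appears only in compound 2, on a related core that allows no direct comparison. Also open, from the compounds shown here alone, is how methylamino, benzylamino or a carboxylic acid on the phenyl ring would read on the shared core.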